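Swapping the dimethylphenyl of compound 2 for 4-hydroxyphenyl

The source may report more compounds than this note shows. Statements on the series, on what has been measured and on what is new or still open speak of the compounds shown alone.

Of the compounds shown here, two have numbers so far. In a functional assay on SW-620 cells (Homo sapiens) for cytotoxicity (a lower number here means a stronger inhibitor of growth, a higher number a weaker inhibitor of growth), compound 1 (`COc1ccc(C2=C(c3ccc(SC)cc3)CC3CCCN3C2=O)cc1OC(=O)C1CCCN1C(=O)OC(C)(C)C`) gives 10000 nM. In the same read-out compound 2 (`CSc1ccc(C2=C(c3ccc(C)c(C)c3)C(=O)N3CCCC3C2)cc1`) gives 700 nM, the lower of the two numbers and beyond the scatter from the other one, so compound 2 is the stronger inhibitor of growth of this pair.

The next compound to be tested is compound 3 (`CSc1ccc(C2=C(c3ccc(O)cc3)C(=O)N3CCCC3C2)cc1`). Among the measured compounds shown here, it carries 4-hydroxyphenyl in place of 3,4-dimethylphenyl on a double-bonded ring carbon, the only change from compound 2: 4-hydroxyphenyl in place of 3,4-dimethylphenyl on a double-bonded ring carbon. The group sits next to the ring atom that bears the 4-(methylsulfanyl)phenyl group, which stays in place.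

For the measured compounds named here, the two measured compounds differ in more than one place, so no measured step speaks to this swap. The expectation therefore starts from compound 2 at 700 nM and stays wide on both sides. The estimated step of a 1.1-fold higher number from compound 2 to compound 3 (0.06 log units; within the scatter) in this assay is expected to stay within the scatter, with no firm direction. For compound 3 the expected value is 800 nM, with an estimated range of 200 nM to 4000 nM.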

Compound 3, concentration for 50% growth inhibition: > 100000 nM
Compound 3 gave a limit, no number; the forecaster's own chance of this, stated with the estimate: 5%; middle value at least 120-fold (2.09 log units) away from the limit.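

In this assay compound 3 gives > 100000 nM, a limit of the assay and not a number. Among the compounds shown here, compound 1 and compound 2 differ in more than one place, so the first reading of a single change is an at least 140-fold higher number from compound 2 to compound 3 (2.15 log units; beyond the scatter), for 4-hydroxyphenyl in place of 3,4-dimethylphenyl on a double-bonded ring carbon, with the 4-(methylsulfanyl)phenyl group kept; both groups hold one six-membered aromatic ring of carbon only, so at this position the presence of that ring alone does not keep growth inhibition, and the substituents on it decide the reading. The full size of this step stays unfixed, and the figure is only a lower bound: the limit of > 100000 nM in this assay, at which 1 of the 3 values shown sits.

The change removes two methyl groups and adds a hydroxyl in one move, so the compounds shown do not separate the effect of the hydroxyl from that of losing the methyl groups. From the compounds shown here alone, how a 4-methylphenyl, a 4-methoxyphenyl or a 4-aminophenyl group would read at this place remains open, as does whether the same swap behaves alike on the core of compound 1.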